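The source may hold more compounds than are shown below. What is called first, only, known or untested is meant among the compounds shown, and "the series" means these compounds.

Compound 1 `O=[N+]([O-])c1cn2c(n1)OC[C@@H](OCc1ccc(-c3ccc(OC(F)(F)F)cc3)cc1)C2` is the parent of this small set. In an ADME assay on Vero cells (Chlorocebus sabaeus) for cytotoxicity, with a stated time of 72 h (on this read-out lower numbers stand for stronger inhibition and higher numbers for weaker inhibition), compound 1 gives > 128000 nM, which is a limit of the assay and not a number. Compound 2 `O=[N+]([O-])c1cn2c(n1)OC[C@@H](OCc1ccc(-c3ccc(OC(F)(F)F)cc3)cc1Cl)C2` carries a chloro in place of hydrogen on an aromatic carbon. In this assay compound 2 gives > 128000 nM, again a limit. Compound 3 `O=[N+]([O-])c1cn2c(n1)OC[C@@H](OCc1ccc(-c3ccc(OC(F)(F)F)cc3)c(Cl)c1)C2` is the second chlorinated analogue. In this assay compound 3 gives > 128000 nM, also a limit. Because of this, the step from compound 1 to compound 2 a step that the two limits leave unreadable from compound 1 to compound 2 and the step from compound 1 to compound 3 a step that the two limits leave unreadable from compound 1 to compound 3 cannot be sized, and compound 2 stands at the limit of > 128000 nM in this assay, at which 3 of the 3 values shown sit.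

Compound 4 `O=[N+]([O-])c1cn2c(n1)OC[C@@H](OCc1c(Cl)cc(-c3ccc(OC(F)(F)F)cc3)cc1Cl)C2` differs from compound 2 by chloro in place of hydrogen on an aromatic carbon. Both measured steps of the same kind, a chloro entering for hydrogen on an aromatic carbon, were left unreadable by the limits, so there is no readable step of this type to draw on. The expectation for compound 4 is therefore a step that the limit leaves unreadable from compound 2 to compound 4 in this assay, with no readable change foreseen. Compound 4 is estimated to give 200000 nM in this assay, within a range from 100000 nM to 500000 nM, most likely reported again as a limit.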

Compound 4, half-maximal inhibitory concentration: > 128000 nM
Compound 4: no number, only a limit; the forecaster's own chance of this, stated with the estimate: 90%; the middle value is on the limit's open side.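

Compound 2 and compound 4 both stand at a limit in this assay, so no size can be read for the step between them: the limit of > 128000 nM in this assay, at which 4 of the 4 values shown sit.

The compounds shown leave open whether a chloro in place of hydrogen on an aromatic carbon changes the read-out of this assay at all, and where any of the four compounds would give an actual number.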